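A few compounds are considered here, and "the series" means these few. Any claim that something is new, unique, unknown or untested is made for them only; others in the source may bear on it.

In an ADME assay on CHO-K1 cells (Cricetulus griseus) for cytotoxicity, read by MTT assay, with a stated time of 24 h (on this read-out lower numbers stand for stronger inhibition and higher numbers for weaker inhibition), two compounds sharing the same core have been measured so far. Compound 1, `CCCCCCCCCCCCn1nnc(-c2cc([N+](=O)[O-])cc([N+](=O)[O-])c2)n1`, reaches only a limit of the assay, and in this assay compound 1 gives > 200000 nM. Compound 2, `Cc1ccc(Cn2nnc(-c3cc([N+](=O)[O-])cc([N+](=O)[O-])c3)n2)cc1`, in this assay gives 200000 nM. Among the measured compounds shown here, that is the only number recorded for compound 2 to stand against; the other result is a limit, as the limit of > 200000 nM in this assay, at which 1 of the 2 values shown sits, shows. Compound 3, `O=[N+]([O-])c1cc(-c2nnn(Cc3ccc(Br)cc3)n2)cc([N+](=O)[O-])c1`, differs from compound 2 by bromo in place of methyl on an aromatic carbon. For the measured compounds named here, no step between two measured compounds is available to say how such a change moves the numbers here. The expected step, no change at the digits printed from compound 2 to compound 3 (within the scatter), is estimated to be no larger than the usual scatter. On that basis compound 3 is estimated at 200000 nM in this assay, with a range from 100000 nM to 400000 nM, and a real chance that only a limit is reported.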

Compound 3, half-maximal inhibitory concentration: 55000 nM
Beside the measured number, compound 3's estimate is 3.6-fold (0.56 log units) above it, and the stated range ends above it.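

Among the compounds shown here, the swap of 4-methylbenzyl for 4-bromobenzyl gives a 3.6-fold lower number from compound 2 to compound 3 (0.56 log units; beyond the scatter) in this assay, the first step that can be read here. It shows that replacing one group at this place on the aromatic ring can move the number beyond the usual scatter, even though the counts of rings, hydrogen-bond donors and hydrogen-bond acceptors stay the same and no net charge enters. Nothing measured here explains why this change has that effect.

A single step cannot show whether bromo is special or whether other replacements for methyl would do the same. Chloro, methoxy, an amine or a carboxylic acid at this place could each lower the number further, leave it unchanged or raise it, and the compounds shown do not settle which.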